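Taking the ethoxy group off compound 2

A few compounds are considered here, and "the series" means these few. Any claim that something is new, unique, unknown or untested is made for them only; others in the source may bear on it.

Compound 1 `CS(=O)(=O)c1ccc2nc(NC(=O)CCCCC(=O)NO)sc2c1`: > 30 ug/mL, a limit of the assay
Compound 2 `CCOc1ccc2nc(NC(=O)CCCCC(=O)NO)sc2c1`: 16.7 ug/mL

Going by the values given here, in a functional assay on ASPC1 cells (Homo sapiens) for cytotoxicity (on this read-out lower numbers stand for stronger inhibition and higher numbers for weaker inhibition), compound 2 gives 16.7 ug/mL, the only actual number so far. The value of compound 1 is a limit. Compound 3 `O=C(CCCCC(=O)Nc1nc2ccccc2s1)NO` differs from compound 2 by hydrogen in place of ethoxy on an aromatic carbon, with hydrogen in place of ethoxy on an aromatic carbon. Among the compounds with values here, the only measured step, an at least 1.7-fold lower number from compound 1 to compound 2 (0.25 log units; that floor lies within the scatter), also involves ethoxy, but it rests on the limit of > 30 ug/mL in this assay, at which 1 of the 2 values shown sits, and fixes no size. No step beyond the scatter is therefore expected in this assay. The expected change is a 1.0-fold lower number from compound 2 to compound 3 (0.02 log units; within the scatter). For compound 3 the estimated value is 16 ug/mL, with an expected range of 7 ug/mL to 35 ug/mL.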

Compound 3, half-maximal inhibitory concentration: 10.2 ug/mL
The estimate for compound 3 lay 1.6-fold (0.20 log units) above the measured number, within the range that was stated.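

In this assay, hydrogen in place of ethoxy gives a 1.6-fold lower number from compound 2 to compound 3 (0.21 log units; within the scatter), so at this position compound 3, with no substituent, stays level with compound 2. Hydrogen in place of methylsulfonyl gives the first step beyond the scatter, an at least 2.9-fold lower number from compound 1 to compound 3 (0.46 log units; beyond the scatter). That step is only a floor, and the value of compound 1 is a limit: the limit of > 30 ug/mL in this assay, at which 1 of the 3 values shown sits.

As far as these compounds go, whether an amine or a carboxylic acid at this position would read like hydrogen and ethoxy or like methylsulfonyl remains open. So does what a longer chain between the amide and the hydroxamic acid would do.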